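Tert-Butyl in Place of Methyl on the Shared Core

The source may hold more compounds than are shown below. What is called first, only, known or untested is meant among the compounds shown, and "the series" means these compounds.

Measured so far:
compound 1 `CCN1CCc2c(c(C)nn2C(=O)Nc2cc(C)ccc2C)C1`, 2.6%
compound 2 `CCN1CCc2c(c(C)nn2C(=O)Nc2ccc(F)cc2F)C1`, 7.8%
compound 3 `CCN1CCc2c(c(C)nn2C(=O)Nc2cccc(C(F)(F)F)c2)C1`, 4.4%

Three compounds share one core and differ only in the aromatic group on the amide nitrogen. In a functional assay on the whole organism (strain Swiss albino) for inhibition, with Mus musculus as the target, in the formalin test, with stated times of 30 min and 5 min, at a dose of 100 mg/kg (a higher number here means more inhibition at the dose given (going by the name of the read-out), a lower number less inhibition), compound 1 gives 2.6%, compound 2 gives 7.8% and compound 3 gives 4.4%. Compound 2 has the highest of the three numbers, but its distance to compound 3 and to compound 1 lies within the usual scatter of repeated measurements, so the three cannot be told apart; all of them inhibit little at this dose.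

Compound 4 `CCN1CCc2c(c(C(C)(C)C)nn2C(=O)Nc2ccc(F)cc2F)C1` keeps the aromatic group of compound 2 and changes the core instead: tert-butyl in place of methyl on an aromatic carbon. Among the compounds with values here, no measured pair shows what such a change does here, so no direction can be taken from the data. Any step from compound 2 to compound 4 in this assay is expected to stay within the scatter, that is a number 0.2 percentage points higher from compound 2 to compound 4 (within the scatter). Compound 4 is therefore expected to give about 8% in this assay, estimated between 0% and 20%.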

Compound 4, a percentage reported as inhibition, in the whole organism at one dose (the size of the read-out at that dose, not a potency): 4.4%
Compound 4: the middle estimate sits 3.6 percentage points above what was measured, within the range that was stated.
By their numbers in this assay, from the lowest: compounds 1, 3, 4 and 2 (each within the scatter of the next).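

In this assay, tert-butyl in place of methyl on this aromatic carbon gives a number 3.4 percentage points lower from compound 2 to compound 4 (within the scatter). Within the data shown here, this is the first pair that differs on the shared core rather than in the aromatic group on the amide nitrogen, and it shows no readable effect of the larger group at this position, in either direction; since compound 2 and compound 4 both inhibit little at this dose, the pair cannot show whether the position matters for inhibition. Nothing available offers an explanation for this result.

Still open, as far as these compounds go, is whether another group on this carbon, such as an amine or a carboxylic acid, would give a number beyond the scatter. From the compounds shown here alone, it is also open whether tert-butyl would read the same alongside the aromatic groups of compound 1 or compound 3.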